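Swapping methyl for chloro on a urotensin-2 receptor agonist

A few compounds are considered here, and "the series" means these few. Any claim that something is new, unique, unknown or untested is made for them only; others in the source may bear on it.

Compound 1 `Cc1ccc(C(CCN(C)C)NC(=O)C#Cc2ccccc2)cc1` and compound 3 `CN(C)CCC(NC(=O)C#Cc1ccccc1)c1ccc(Cl)cc1` share one core and differ only by chloro in place of methyl on an aromatic carbon. In a functional assay on NIH3T3 cells for agonist activity at Urotensin-2 receptor (Homo sapiens), with a stated time of 5 days (on this read-out higher numbers stand for larger maximal responses and lower numbers for smaller maximal responses), compound 1 gives 131%, and compound 3 gives 124%; the change made a number 7 percentage points lower from compound 1 to compound 3 (within the scatter). Compound 2 `COc1ccc(/C=C/C(=O)NC(CCN(C)C)c2ccc(C)cc2)cc1` is built on a different core; how the two cores differ is not broken down here. In this assay compound 2 gives 79%, the smallest response of the three, sitting well below both compound 3 and compound 1. Compound 4 `COc1ccc(/C=C/C(=O)NC(CCN(C)C)c2ccc(Cl)cc2)cc1` has not yet been measured. It differs from compound 2 by chloro in place of methyl on an aromatic carbon, the same change already seen from compound 1 to compound 3, at the same kind of place. Since that earlier swap on the other core stayed within the scatter, as a number 7 percentage points lower from compound 1 to compound 3 (within the scatter) shows, the expectation for compound 4 in this assay is a step of a number 5 percentage points lower from compound 2 to compound 4 (within the scatter). On that footing compound 4 is estimated at 74%, with a likely range from 55% to 95%.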

Compound 4, largest response reached (reported as efficacy), in percent of the reference or control that the assay uses: 99%
Beside the measured number, compound 4's estimate is 25 percentage points below it; the measured number lies above the stated range.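

In this assay, changing 4-methylphenyl to 4-chlorophenyl on the core of compound 2 gives a number 20 percentage points higher from compound 2 to compound 4 (beyond the scatter), so on this core the swap raises the maximal response. The same swap therefore does not behave as one fixed step that can be carried unchanged from one core to the other: the same change on two cores in this assay, a number 7 percentage points lower (within the scatter) from compound 1 to compound 3 and a number 20 percentage points higher (beyond the scatter) from compound 2 to compound 4, 27 percentage points apart, beyond the scatter of two such steps. This shows that, for these two pairs, the outcome of the swap differs with the core, but two pairs cannot show which part of the cores matters or predict the step on a third core.

The compounds shown carry only methyl or chloro at this place on the ring, so it remains open whether fluoro or a nitrile there would give a response closer to that of the methyl or the chloro compounds on either core. Also open, going by these compounds, is how the response would change if a primary amine replaced the dimethylamino group on the chain.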